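Working notes: amino for fluoro in the styryl sulfonamide series

The source may hold more compounds than are shown below. What is called first, only, known or untested is meant among the compounds shown, and "the series" means these compounds.

- compound 1 `O=S(=O)(/C=C/c1ccccc1)Nc1ccccc1` gives 10000 nM
- compound 2 `COc1cc(OC)c(/C=C/S(=O)(=O)Nc2cc(N)c(OC)c(N)c2)c(OC)c1` gives 2500 nM
- compound 3 `COc1ccc(NS(=O)(=O)/C=C/c2c(F)c(F)c(F)c(F)c2F)cc1F` gives 10000 nM

In a functional assay on DU-145 cells (Homo sapiens) for cytotoxicity, read by trypan blue exclusion, with a stated time of 96 h (on this read-out lower numbers stand for stronger inhibition and higher numbers for weaker inhibition), compound 1 is level with compound 3 at 10000 nM as the highest of the three numbers, while compound 2 stands lower at 2500 nM. That gap lies beyond the scatter. Going to compound 4 `COc1ccc(NS(=O)(=O)/C=C/c2c(F)c(F)c(F)c(F)c2F)cc1N` puts amino in place of fluoro on an aromatic carbon, ortho to a methoxy group, with amino in place of fluoro on an aromatic carbon as the count of the change. Going by the values given here, no measured pair isolates this change. Among the compounds with values here, compound 2, the only measured compound carrying amino groups, gives 2500 nM but differs from compound 3 in other places too, so a move to a lower number, beyond the scatter, is expected with low confidence. The estimated move is a 6.7-fold lower number from compound 3 to compound 4 (0.82 log units; beyond the scatter) on this reading. Compound 4 is expected at 1500 nM with an estimated range of 150 nM to 10000 nM for now.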

Compound 4, half-maximal inhibitory concentration: 75000 nM
Compound 4: middle estimate off by 50-fold (1.70 log units), on the low side, outside the stated range (above it).
By their numbers in this assay, from the lowest: compound 2; then compounds 1 and 3 (each within the scatter of the next); then compound 4.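

In this assay, amino in place of fluoro on an aromatic carbon, ortho to a methoxy group, gives a 7.5-fold higher number from compound 3 to compound 4 (0.88 log units; beyond the scatter). Going by these compounds alone, this is the first pair to isolate the change, and at this position amino weakens inhibition, so the amino groups of compound 2 do not carry over to this place. Nothing measured here bears on the reason for the step.

Open, as far as these compounds go, is whether a hydroxyl group or an acetamide at this same place would stay level with fluoro or follow amino. Also open, from the compounds shown here alone, is whether a methyl group would separate either result from that of compound 3.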